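The source may hold more compounds than are shown below. What is called first, only, known or untested is meant among the compounds shown, and "the series" means these compounds.

Measured so far:
compound 1 `CC(C)=CCC1=C(OCc2cn(C3CCN(C(=O)OC(C)(C)C)CC3)nn2)C(=O)c2ccccc2C1=O` — in an ADME assay on HepG2 cells (Homo sapiens) for cytotoxicity, read by MTT assay, with a stated time of 24 h (a lower number here means that less compound is tolerated, a higher number that more compound is tolerated), compound 1 gives 136000 nM
compound 2 `CC(C)=CCC1=C(OCc2cn(-c3cccc(F)c3)nn2)C(=O)c2ccccc2C1=O` — in this assay compound 2 gives 265000 nM

Compound 2 and compound 1 lie within the usual scatter of each other, so the two numbers separate nothing yet. Compound 3 `COc1ccc(-n2cc(COC3=C(CC=C(C)C)C(=O)c4ccccc4C3=O)nn2)c([N+](=O)[O-])c1` carries the change (4-methoxy-2-nitrophenyl in place of 3-fluorophenyl on an aromatic nitrogen), that is, 4-methoxy-2-nitrophenyl in place of 3-fluorophenyl on an aromatic nitrogen. Among the compounds with values here, no measured pair here shows a step of this kind, so nothing beyond the scatter is expected, in either direction; the expected step is a 1.2-fold lower number from compound 2 to compound 3 (0.08 log units; within the scatter). Compound 3 is thus estimated at 220000 nM in this assay, with a range of 90000 nM to 500000 nM.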

Compound 3, half-maximal cytotoxic concentration: 532000 nM
Compound 3: middle estimate off by 2.4-fold (0.38 log units), on the low side, outside the stated range (above it).
By their numbers in this assay, from the lowest: compounds 1, 2 and 3 (each within the scatter of the next, the first and the last beyond it).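

On the aromatic nitrogen of the five-membered ring, 4-methoxy-2-nitrophenyl in place of 3-fluorophenyl gives a 2.0-fold higher number from compound 2 to compound 3 (0.30 log units; within the scatter) in this assay. This position therefore takes a larger substituted phenyl carrying nitro and methoxy groups without a step beyond the scatter. No measurement on hand bears on the cause of this step.

As far as these compounds go, whether the nitro or the methoxy group alone would give a similar number remains open. So does the outcome in this assay for a phenyl ring carrying an amine or a carboxylic acid.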